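Stilbene series: demethylation step, cytotoxicity on liver cells

A few compounds are considered here, and "the series" means these few. Any claim that something is new, unique, unknown or untested is made for them only; others in the source may bear on it.

Measured so far:
compound 1, `COc1c(O)cccc1/C=C/c1cc(O)cc(O)c1`, > 100000 nM
compound 2, `COc1cc(O)cc(/C=C/c2cccc(OC)c2OC)c1`, 80500 nM

In a functional assay on FHCC-98 cells (Homo sapiens) for cytotoxicity, read by MTT assay, with a stated time of 24 h (a lower number here means a stronger inhibitor, a higher number a weaker inhibitor), compound 1 gives only a limit, > 100000 nM, which is not a number; it stands at the limit of > 100000 nM in this assay, at which 1 of the 2 values shown sits. In this assay, among the compounds with values here, compound 2 gives 80500 nM, the only numerical value in the set so far. There is thus nothing numerical to place it against. Within the data shown here, no pair of measured compounds differing in a single place is available, and no step size is therefore known.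

Compound 3, `COc1cc(O)cc(/C=C/c2cccc(O)c2OC)c1`, has not been measured in this assay. It differs from compound 2 by hydrogen in place of methyl on an oxygen on an aromatic ring. With no measured step of this kind in the series, the expectation for the step from compound 2 to compound 3 is a 1.1-fold higher number from compound 2 to compound 3 (0.05 log units; within the scatter), that is, no change beyond the usual scatter of the assay, in either direction. On that basis compound 3 is estimated to give 90000 nM, with a range from 30000 nM to 300000 nM, and a real chance that the assay returns only a limit, as it did for compound 1.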

Compound 3, half-maximal inhibitory concentration: > 100000 nM
Compound 3 gave a limit, no number; the forecaster's own chance of this, stated with the estimate: 45%; middle value at least 1.1-fold (0.04 log units) away from the limit.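

In this assay, the series now has its first measured pair differing in one place, and the methoxy to hydroxy change on this oxygen on an aromatic ring gives an at least 1.2-fold higher number from compound 2 to compound 3 (0.09 log units; that floor lies within the scatter). Compound 3 gives only a limit, > 100000 nM, so this step is a floor: it shows no sign of a lower number with the methyl gone, but it does not separate the pair beyond the usual scatter. The step between compound 1 and compound 3 cannot be read, and the set now gathers at one point: the limit of > 100000 nM in this assay, at which 2 of the 3 values shown sit.

As far as these compounds go, the true size of the step stays open, as does whether the same methoxy to hydroxy change at another oxygen of the shared core would read the same way. Also open, from the compounds shown here alone, is whether a longer chain in place of the methyl on this oxygen, or an amine or a carboxylic acid in place of the hydroxy, would give a readable number in this assay.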